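Cyclopropyl for dimethylamino on the pyridyl of compound 2

This account rests on a few compounds, and the source may have more. Where it says the series, first, only, none or still open, it means among the compounds named here.

Compound 1 `C[C@H](NC(=O)c1cc(C(F)(F)F)nn1C)c1nc(-c2cccc(F)c2)no1` gives 136 nM in an assay on T-REx-293 cells for inhibition of potassium channel subfamily T member 1 (Homo sapiens), read by patch clamp; on this read-out higher numbers stand for weaker inhibition and lower numbers for stronger inhibition. Compound 2 `C[C@H](NC(=O)c1cc(C(F)(F)F)nn1C)c1nc(-c2ccnc(N(C)C)c2)no1` gives 454 nM in this assay.

Within the data shown here, compound 2 stands at the higher of the two numbers measured so far: the step of a 3.3-fold higher number from compound 1 to compound 2 (0.52 log units; beyond the scatter) is beyond the scatter. Compound 3 `C[C@H](NC(=O)c1cc(C(F)(F)F)nn1C)c1nc(-c2ccnc(C3CC3)c2)no1` has not been measured; it differs from compound 2 by cyclopropyl in place of dimethylamino on an aromatic carbon. No measured step exchanges one group for another at this place, since the only step shown, a 3.3-fold higher number from compound 1 to compound 2 (0.52 log units; beyond the scatter), replaces the whole ring and does not bear directly on this change. The step of a 1.5-fold lower number from compound 2 to compound 3 (0.18 log units; within the scatter) is therefore expected to be small, with a direction that the data cannot settle. Compound 3 is estimated at 300 nM in this assay, with a range from 100 nM to 900 nM.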

Compound 3, half-maximal inhibitory concentration: 16 nM
Estimate against measurement, compound 3: 19-fold (1.27 log units) above; the measured number lies below the stated range.
By their numbers in this assay, from the lowest: compound 3; then compound 1; then compound 2.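

In this assay, exchanging dimethylamino for cyclopropyl on the aromatic carbon next to the ring nitrogen keeps the heavy-atom count the same, yet it gives a 28-fold lower number from compound 2 to compound 3 (1.45 log units; beyond the scatter) and so shows that this position responds strongly to the group it carries. The ring with one nitrogen is also no drawback in itself, since 2-cyclopropylpyridin-4-yl in place of 3-fluorophenyl gives an 8.5-fold lower number from compound 1 to compound 3 (0.93 log units; beyond the scatter). This reverses the order seen between compound 1 and compound 2. No measurement given here accounts for either step.

The compounds shown do not separate the contribution of the three-membered ring from that of replacing the amine nitrogen with carbon. From the compounds shown here alone, an isopropyl, a cyclobutyl or a methoxy group at this carbon, or a cyclopropyl on a phenyl ring, remains open.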